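Extending a Trifluoromethyl Urea Series Toward a Chloro Analogue

This account rests on a few compounds, and the source may have more. Where it says the series, first, only, none or still open, it means among the compounds named here.

Measured so far in a functional assay on RXF 393 cells (Homo sapiens) for inhibition, read by sulforhodamine B assay, with a stated time of 48 h; on this read-out lower numbers stand for higher toxicity in this test and higher numbers for lower toxicity in this test:
compound 1 `O=C(Nc1cccc(-n2cc(-c3ccncc3)c(-c3ccc(Cl)c(O)c3)n2)c1)Nc1cccc(C(F)(F)F)c1`, with a limit of > 32500 nM.
compound 2 `COc1cc(-c2nn(-c3cccc(NC(=O)c4cccc(C(F)(F)F)c4)c3)cc2-c2ccncc2)ccc1Cl`, with a limit of > 50000 nM.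
compound 3 `O=C(Nc1cccc(-n2cc(-c3ccncc3)c(-c3ccc(Cl)c(O)c3)n2)c1)Nc1cc(C(F)(F)F)cc(C(F)(F)F)c1`, at 10700 nM.

Compound 2 carries a trifluoromethyl-substituted amide on the shared core and reaches only a limit in this assay, so its place among the numbers shown is open; it sits at the limit of > 50000 nM in this assay, at which 1 of the 3 values shown sits, and compound 1 sits at the limit of > 32500 nM in this assay, at which 1 of the 3 values shown sits. Compound 4 `COc1cc(-c2nn(-c3cccc(NC(=O)Nc4ccc(Cl)c(C(F)(F)F)c4)c3)cc2-c2ccncc2)ccc1Cl` differs from compound 2 by (4-chloro-3-(trifluoromethyl)phenyl)amino in place of 3-(trifluoromethyl)phenyl on a carbonyl carbon, turning the amide into a urea and adding a chlorine. Among the measured compounds shown here, the only measured step that touches this kind of change is an at least 3.0-fold lower number from compound 1 to compound 3 (0.48 log units; beyond the scatter), where adding a trifluoromethyl group on a urea aryl ring brought the number down. For the measured compounds named here, by analogy, adding a chlorine to the urea aryl ring of compound 4 is expected to give a modestly lower number than compound 2, though the change from amide to urea has no measured counterpart here, so the estimate is uncertain and may again end as a limit. For compound 4 the estimated value in this assay is 20000 nM, with a range from 7000 nM to 60000 nM, an expected step of an at least 2.5-fold lower number from compound 2 to compound 4 (0.39 log units; beyond the scatter).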

Compound 4, concentration lethal to 50% of the cells: > 32500 nM
Compound 4: no number, only a limit (the forecaster's own chance of this, stated with the estimate: 40%); at least 1.6-fold (0.21 log units) between middle value and limit.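

Compound 2 and compound 4 each give only a limit of the assay, not a number, so the step between them cannot be read. The compounds shown leave open whether compound 4, with its urea, and compound 2, with its amide, truly differ in this assay.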